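Methoxy for Fluoro on an Imidazoline Aniline Scaffold

The source may report more compounds than this note shows. Statements on the series, on what has been measured and on what is new or still open speak of the compounds shown alone.

Measured compounds:
compound 1, `COc1ccc(S(C)(=O)=O)c(NCC2=NCCN2)c1`, 4570 nM
compound 2, `CSc1ccc(C)cc1NCC1=NCCN1`, 123 nM
compound 3, `CSc1ccc(F)cc1NCC1=NCCN1`, 40.7 nM

Compound 3 gives the lowest number of the three in an assay for binding affinity to Alpha-1B adrenergic receptor (Homo sapiens), read by radioligand binding; on this read-out lower numbers stand for stronger inhibition and higher numbers for weaker inhibition; compound 2 sits nearest, and compound 1 furthest. Among the measured compounds shown here, the one single-site step on record is a 3.0-fold lower number from compound 2 to compound 3 (0.48 log units; beyond the scatter), a modest gain. Compound 4, `COc1ccc(SC)c(NCC2=NCCN2)c1`, arises from compound 3 by methoxy in place of fluoro on an aromatic carbon. For the measured compounds named here, no measured pair shows this exact exchange; the only guidance is that a larger group at this position, as in compound 2, went with a higher number than compound 3 in this assay. Compound 4 is therefore expected to give a somewhat higher number, an estimated 2.9-fold higher number from compound 3 to compound 4 (0.47 log units; beyond the scatter), landing around 120 nM with a range from 40 nM to 400 nM.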

Compound 4, inhibition constant: 692 nM
The estimate for compound 4 lay 5.8-fold (0.76 log units) below the measured number, and the stated range ends below it.
By their numbers in this assay, from the lowest: compound 3; then compound 2; then compound 4; then compound 1.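

In this assay methoxy in place of fluoro gives a 17-fold higher number from compound 3 to compound 4 (1.23 log units; beyond the scatter) and methoxy in place of methyl gives a 5.6-fold higher number from compound 2 to compound 4 (0.75 log units; beyond the scatter), so at this position methoxy goes with a higher number than either earlier group. With methoxy kept, methylsulfanyl in place of methylsulfonyl gives a 6.6-fold lower number from compound 1 to compound 4 (0.82 log units; beyond the scatter) and shows that the other position still moves the number with this group present. Nothing measured here explains the penalty for methoxy.

The compounds shown leave open how a hydroxy group, a chlorine atom or an ethoxy group would fare at this position. They also leave open whether the fluoro compound's standing would hold with methylsulfonyl in place of methylsulfanyl.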